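Flipping one ring stereocentre in an ethynyl nucleoside

The compounds below may be only part of what the source reports. "The series", "measured", "known", "first", "only" and "open" are said of these compounds alone.

Compound 1 `C#C[C@@H]1[C@@H](O)[C@H](n2ccc(=O)[nH]c2=O)O[C@@H]1CO`: > 350000 nM
Compound 2 `C#C[C@]1(O)[C@@H](CO)O[C@@H](n2ccc(=O)[nH]c2=O)[C@@H]1O`: > 350000 nM; 130 nM (2 entries)
Compound 3 `Nc1ccn([C@@H]2O[C@H](CO)[C@](O)(C3CC3)[C@H]2O)c(=O)n1`: > 350000 nM

All three measured compounds were tested in a functional assay on L1210 cells (Mus musculus), read by MTT assay; a lower number here means a stronger inhibitor, a higher number a weaker inhibitor. For compound 1 the result is only a limit of the assay, > 350000 nM, not a number. Compound 3 likewise reaches only the limit, > 350000 nM. Among the measured compounds shown here, compound 2 is the one measured compound with a number among its entries, > 350000 nM; 130 nM (2 entries). Its entries do not agree with one another, as the several entries of compound 2 in this assay, > 350000 nM; 130 nM (2 entries) shows. So, on the numbers shown, compound 1 stands at the weak end, at the limit where the limit of > 350000 nM in this assay, at which 2 of the 3 values shown sit, sit.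

Compound 4 `C#C[C@H]1[C@@H](O)[C@H](n2ccc(=O)[nH]c2=O)O[C@@H]1CO` has not yet been measured. It differs from compound 1 only in configuration: the two compounds have the same atoms and bonds and differ only in configuration as drawn: 1 of 4 stereo elements differ; a stereocentre at a saturated ring carbon is drawn R in compound 1 and S in compound 4. For the measured compounds named here, no step between measured compounds is available to say what such a flip does here.

With compound 1 giving only a limit, compound 4 is expected to stay near that limit as well, and most likely to be reported as a limit too. The expected step from compound 1 to compound 4 is an at least 1.4-fold lower number from compound 1 to compound 4 (0.14 log units; that floor lies within the scatter), which is taken as no change beyond the scatter. Compound 4 is therefore estimated at 250000 nM, in a range from 20000 nM to 350000 nM.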

Compound 4, half-maximal inhibitory concentration: > 350000 nM
Compound 4: no number, only a limit; the forecaster's own chance of this, stated with the estimate: 70%; at least 1.4-fold (0.14 log units) between middle value and limit.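

In this assay compound 4 gives > 350000 nM, which is a limit and not a number. Among the compounds shown here, compound 1 gives > 350000 nM, also a limit, so no step between compound 1 and compound 4 can be read. The compounds shown leave open whether the stereocentre, drawn R in compound 1 and S in compound 4, changes activity at all.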